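The compounds below may be only part of what the source reports. "The series", "measured", "known", "first", "only" and "open" are said of these compounds alone.

Measured in a functional assay on A2780 cells (Homo sapiens) for inhibition, read by sulforhodamine B assay, with a stated time of 72 h; a higher number here means a weaker inhibitor, a lower number a stronger inhibitor:
compound 1 `O=C(NCc1ccc(S(=O)(=O)N2CCCCC2)cc1)c1cc2cnccc2s1`: 1600 nM
compound 2 `O=C(NCc1ccc(S(=O)(=O)N2CCCCC2)cc1)c1ccn2cncc2c1`: only a limit, > 10000 nM
compound 3 `O=C(NCc1ccc(S(=O)(=O)N2CCCCC2)cc1)c1cnc2nccn2c1`: 130 nM

Compound 3 stands at the lowest of the two numbers shown; compound 1 is the nearest, and the step of a 12-fold lower number from compound 1 to compound 3 (1.09 log units; beyond the scatter) lies beyond the scatter. For compound 2 the assay gives no number but a limit, (the limit of > 10000 nM in this assay, at which 1 of the 3 values shown sits). The remaining steps also exchange the group on the carbonyl carbon: an at least 6.2-fold higher number from compound 1 to compound 2 (0.79 log units; beyond the scatter), and an at least 76-fold lower number from compound 2 to compound 3 (1.88 log units; beyond the scatter), the latter read against a limit.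

Compound 4 `O=C(NCc1ccc(S(=O)(=O)c2cccc(C(F)(F)F)c2)cc1)c1cnc2nccn2c1` keeps the core of compound 3 and alters a different place: 3-(trifluoromethyl)phenyl in place of piperidin-1-yl on a sulfonyl sulfur. Among the compounds with values here, none of the three measured steps touches the sulfonyl sulfur; all of them vary the group on the carbonyl carbon, so nothing among the measured compounds speaks to this exchange. As far as these compounds go, compound 4 is therefore expected to show no step beyond the scatter, a 1.2-fold higher number from compound 3 to compound 4 (0.06 log units; within the scatter), though with a wide range since the position is untested in this set. The estimate for compound 4 in this assay is 150 nM, between 35 nM and 700 nM.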

Compound 4, half-maximal inhibitory concentration: 2 nM
Compound 4: middle estimate off by 75-fold (1.88 log units), on the high side, outside the stated range (below it).
By their numbers in this assay, from the lowest: compound 4; then compound 3; then compound 1. At a limit, above all of these: compound 2.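

Measured in this assay the exchange of piperidin-1-yl for 3-(trifluoromethyl)phenyl on the sulfonyl sulfur gives a 65-fold lower number from compound 3 to compound 4 (1.81 log units; beyond the scatter) and so marks this place as one where the series responds strongly. Within the data shown here, the earlier compounds vary only the group on the carbonyl carbon, and this step is larger than the one step there read between two numbers, a 12-fold lower number from compound 1 to compound 3 (1.09 log units; beyond the scatter), so the sulfonyl sulfur now counts as a second place that moves the number, with the larger of these two steps. No measurement shown gives a cause for this step.

Still open, as far as these compounds go, is whether the step belongs to the aromatic ring of carbon only or to the trifluoromethyl group, since the two enter together and a plain phenyl on the sulfonyl sulfur would separate them. Also open, from the compounds shown here alone, are the reach of this place, for example with a morpholine ring or a 3-methoxyphenyl group on the sulfonyl sulfur, and whether 3-(trifluoromethyl)phenyl gives a step of similar size on the core of compound 1.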